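The source may report more compounds than this note shows. Statements on the series, on what has been measured and on what is new or still open speak of the compounds shown alone.

Working notes on the series, all read in a functional assay on UACC-62 cells (Homo sapiens) for cytotoxicity, read by MTT assay, with a stated time of 6 days; a lower number here means a stronger inhibitor, a higher number a weaker inhibitor. For the measured compounds named here, compound 1 (`CC(=O)N[C@@H](CSC(=O)Nc1ccc(Br)cc1)C(=O)O`) gives 320 nM, the only true number so far. Compound 2 (`CC(=O)N[C@@H](CSC(=O)NCc1ccc(Cl)cc1)C(=O)O`) gives > 200000 nM, which is a limit of the assay and not a number. Compound 3 (`COc1ccccc1CNC(=O)SC[C@H](NC(C)=O)C(=O)O`) gives > 200000 nM, again a limit of the assay and not a number. Going by the values given here, compound 1 is therefore the single numeric anchor, and the series holds no measured pair differing in one place from which to size a change.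

Next in line is compound 4 (`CC(=O)N[C@@H](CSC(=O)Nc1ccc(I)cc1)C(=O)O`), which keeps the core of compound 1 and alters one substituent: iodo in place of bromo on an aromatic carbon. In words, this is iodo in place of bromo on an aromatic carbon. As far as these compounds go, no measured comparison between halogens exists, so the direction stays open, and no step beyond the scatter is expected in this assay. That expectation rests on compound 1 at 320 nM, with the range kept wide around a single point. The expected step is a 1.1-fold lower number from compound 1 to compound 4 (0.03 log units; within the scatter). For compound 4 the estimated value is 300 nM, with an expected range of 100 nM to 1000 nM.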

Compound 4, half-maximal inhibitory concentration: 46200 nM
Compound 4: the middle estimate sits 150-fold (2.19 log units) below what was measured; the whole stated range lies below it.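

In this assay, for the compounds shown here, swapping a single halogen on an aromatic carbon, para to a large group, gives a 140-fold higher number from compound 1 to compound 4 (2.16 log units; beyond the scatter), the first sized step. This place is therefore not indifferent to which halogen it carries: the exchange involves one heavy atom for one heavy atom, with no ring, no hydrogen-bond donors or acceptors and no net charge on either side, yet the step lies well beyond the scatter. Compound 4 also still reads as a true number and not as a limit, so this step can be sized in full, unlike any comparison with the values at the assay's limit: the limit of > 200000 nM in this assay, at which 2 of the 4 values shown sit.

As far as these compounds go, with only bromo and iodo read at this place, two points cannot give a trend, and it remains open whether bromo is a narrow optimum or whether a fluoro, a chloro, a methyl or a nitrile there would land nearer compound 1 or nearer compound 4. The data give no cause for the step, and it is also unknown whether the same exchange would carry the same size at another place on the ring.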